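Methyl Added to the Core: Cytotoxicity of Four Compounds

This account rests on a few compounds, and the source may have more. Where it says the series, first, only, none or still open, it means among the compounds named here.

Measured compounds: compound 1 `Cc1ccc(C(=O)c2cc(Cl)ccc2Oc2ccnc(Nc3ccc(C#N)cc3)n2)cc1` gives 1710 nM in an ADME assay on MT4 cells (Homo sapiens) for cytotoxicity, read by MTT assay, with a stated time of 5 days; a lower number here means that less compound is tolerated, a higher number that more compound is tolerated; compound 2 `N#Cc1ccc(Nc2nccc(Oc3ccc(C(=O)c4ccc(O)cc4)cc3)n2)cc1` gives 19400 nM; compound 3 `Cc1ccc(C(=O)c2cc(Cl)ccc2Oc2cc(C)nc(Nc3ccc(C#N)cc3)n2)cc1` gives 26600 nM.

Compound 3 differs from compound 1 by methyl in place of hydrogen on an aromatic carbon, and that change made a 16-fold higher number from compound 1 to compound 3 (1.19 log units; beyond the scatter). The difference between the cores of compound 1 and compound 2 is not broken down here. Compound 4 `Cc1cnc(Nc2ccc(C#N)cc2)nc1Oc1ccc(C(=O)c2ccc(O)cc2)cc1` is not yet measured; it differs from compound 2 by methyl in place of hydrogen on an aromatic carbon. This is the same kind of change as from compound 1 to compound 3, not the same: in compound 3 the methyl sits next to the ring nitrogen, meta to the (4-cyanophenyl)amino group, meta to a large group and opposite the ring nitrogen, whereas in compound 4 it sits ortho to a large group, two atoms from the ring nitrogen and para to the (4-cyanophenyl)amino group. A step of a 2.1-fold higher number from compound 2 to compound 4 (0.31 log units; beyond the scatter) is expected in this assay, smaller than the earlier step, since the place differs and because compound 2 already gives 19400 nM. Compound 4 is therefore estimated at 40000 nM, between 15000 nM and 120000 nM.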

Compound 4, half-maximal cytotoxic concentration: > 295000 nM
Compound 4: a limit, no number; the forecaster's own chance of this, stated with the estimate: 25%; middle value at least 7.3-fold (0.86 log units) from the limit.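

In this assay compound 4 gives > 295000 nM, which is a limit of the assay and not a number. Methyl in place of hydrogen on an aromatic carbon thus gave an at least 15-fold higher number from compound 2 to compound 4 (1.18 log units; beyond the scatter), so on both cores, and at different places on the ring, the change moved the number upward: the same change on two cores in this assay, a 16-fold higher number (1.19 log units; beyond the scatter) from compound 1 to compound 3 and an at least 15-fold higher number (1.18 log units; beyond the scatter) from compound 2 to compound 4; the limit leaves it open whether they differ

How large the step on the core of compound 2 really is stays unsettled, since the reading for compound 4 stops at the limit of the assay: the limit of > 295000 nM in this assay, at which 1 of the 4 values shown sits.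

The compounds shown leave open whether an ethyl group or an amine on the same aromatic carbon would move the number in the same direction. They also leave open whether methyl would do so on a third core.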